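Removing one bromine from a dibromophenol hydrazone

This account rests on a few compounds, and the source may have more. Where it says the series, first, only, none or still open, it means among the compounds named here.

Measured compounds:
- compound 1 `CN(C)CCn1cnnc1-c1cc(Oc2ccc(NC(=O)N/N=C/c3cccc(Br)c3)cc2F)ccn1`: 4230 nM
- compound 2 `CN(C)CCn1cnnc1-c1cc(Oc2ccc(NC(=O)N/N=C/c3cccc(O)c3)cc2F)ccn1`: "not determined" (no result reported)
- compound 3 `CN(C)CCn1cnnc1-c1cc(Oc2ccc(NC(=O)N/N=C/c3cc(Br)c(O)c(Br)c3)cc2F)ccn1`: "not determined" (no result reported)

Three compounds share one core and differ only in the aryl part of the hydrazone. Within the data shown here, in an ADME assay on WI-38 cells (Homo sapiens) for cytotoxicity, read by MTT assay, with a stated time of 72 h (on this read-out higher numbers stand for weaker inhibition and lower numbers for stronger inhibition), compound 1 gives 4230 nM, and this is the only number in the set. Compound 2 gives "not determined" (no result reported) in this assay. Compound 3, the 3,5-dibromo-4-hydroxyphenyl member, likewise gives "not determined" (no result reported) in this assay, so compound 3 stands without a number, alongside one further entry without a number.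

Compound 4 `CN(C)CCn1cnnc1-c1cc(Oc2ccc(NC(=O)N/N=C/c3ccc(O)c(Br)c3)cc2F)ccn1` differs from compound 3 by hydrogen in place of bromo on an aromatic carbon. Among the measured compounds shown here, no step between two measured compounds is available to calibrate this change. Since compound 3 has no value, the expectation for compound 4 rests on compound 1 alone, whose value in this assay is 4230 nM, and a step of size within the scatter, in no particular direction, is expected for such a change in the hydrazone aryl group. Compound 4 is therefore estimated at 4500 nM in this assay, expected to lie between 1500 nM and 15000 nM.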

Compound 4, half-maximal inhibitory concentration: 5560 nM
Estimate against measurement, compound 4: 1.2-fold (0.09 log units) below; low and high end bracket the measured number.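

In this assay the set now holds its first readable comparison, hydroxy in place of hydrogen on an aromatic carbon of the hydrazone aryl group (a 1.3-fold higher number from compound 1 to compound 4 (0.12 log units; within the scatter)), and that step lies within the scatter. With a bromo group on the same aryl group, this hydroxy group therefore makes no measurable difference to the cytotoxicity number here, while the step that removes one bromine from the 3,5-dibromo-4-hydroxyphenyl group cannot be read, as compound 3 has no number. No supporting evidence bears on this result.

The compounds shown leave open what the second bromine contributes and whether the hydroxy group behaves alike without any bromine. They also leave open what a methoxy group in place of the hydroxy, or an amine or a carboxylic acid at this position, would do to the number.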